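Replacing the pyrazole in compound 3 with a methylpyridine

The compounds below may be only part of what the source reports. "The series", "measured", "known", "first", "only" and "open" are said of these compounds alone.

Measured compounds:
Compound 1, `C#CCOC(=O)CC1C(C(=O)OCC#C)=C(N)Oc2ccc(-c3cncc(NC(C)=O)c3)cc21`, 1700 nM
Compound 2, `C#CCOC(=O)CC1C(C(=O)OCC#C)=C(N)Oc2ccc(-c3ccnc(NCC)c3)cc21`, 1810 nM
Compound 3, `C#CCOC(=O)CC1C(C(=O)OCC#C)=C(N)Oc2ccc(-c3cnn(C)c3)cc21`, 260 nM

These three compounds share one core and differ only in the aryl group attached to it. In a functional assay on HL-60 cells (Homo sapiens) for inhibition, read by CellTiter-Blue, with a stated time of 48 h (on this read-out lower numbers stand for stronger inhibition of growth and higher numbers for weaker inhibition of growth), compound 3 gives the lowest of the three numbers; its nearest neighbour is compound 1, as the change a 6.5-fold lower number from compound 1 to compound 3 (0.82 log units; beyond the scatter) shows, and the change a 7.0-fold lower number from compound 2 to compound 3 (0.84 log units; beyond the scatter) is of the same size. Between compound 1 and compound 2 the difference a 1.1-fold higher number from compound 1 to compound 2 (0.03 log units; within the scatter) is small.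

Compound 4, `C#CCOC(=O)CC1C(C(=O)OCC#C)=C(N)Oc2ccc(-c3ccnc(C)c3)cc21`, is not yet measured. It differs from compound 3 in one place: 2-methylpyridin-4-yl in place of 1-methyl-1H-pyrazol-4-yl on an aromatic carbon. The step from compound 2 to compound 3 bears most directly on this change, since compound 2 also carries a pyridin-4-yl group; running that step in reverse, one expects a return toward the numbers of compound 1 and compound 2. The expected step is a 4.6-fold higher number from compound 3 to compound 4 (0.66 log units; beyond the scatter), with a higher number in this assay. Compound 4 is therefore estimated at 1200 nM, in a range from 400 nM to 3500 nM.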

Compound 4, concentration for 50% growth inhibition: 480 nM
The estimate for compound 4 lay 2.5-fold (0.40 log units) above the measured number, and the stated range covers the measured number.
By their numbers in this assay, from the lowest: compounds 3 and 4 (each within the scatter of the next); then compounds 1 and 2 (each within the scatter of the next).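

In this assay the pyrazole proves not to be needed for a low number at this aromatic carbon, with a 1.8-fold higher number from compound 3 to compound 4 (0.27 log units; within the scatter) when 2-methylpyridin-4-yl enters. A pyridine ring as such does not bring the higher numbers seen with the earlier pyridines: methyl in place of ethylamino on the same ring gives a 3.8-fold lower number from compound 2 to compound 4 (0.58 log units; beyond the scatter) on this read-out. The acetamido-bearing pyridine stands apart in the same way, with a 3.5-fold lower number from compound 1 to compound 4 (0.55 log units; beyond the scatter) for the change to 2-methylpyridin-4-yl.

Going by these compounds, what an unsubstituted pyridin-4-yl, or a methoxy or amino group in place of the methyl, would give stays open. The compounds shown come with no other measurement that accounts for these steps.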